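The source may hold more compounds than are shown below. What is called first, only, known or untested is meant among the compounds shown, and "the series" means these compounds.

Measured so far:
compound 1, `Cc1ccc2nc(C(=O)Nc3c(F)cc(-c4cccc(F)c4)cc3F)c(C)c(C(=O)O)c2c1`: 9.25%
compound 2, `CCOc1ccc2nc(C(=O)Nc3c(F)cc(-c4cccc(F)c4)cc3F)c(C)c(C(=O)O)c2c1`: 35.2%

Among the measured compounds shown here, in a functional assay on A-375 cells (Homo sapiens) for antiproliferative activity, read by MTT assay, with a stated time of 24 h, tested at 3.7 ug/mL (on this read-out higher numbers stand for a stronger effect at the one concentration tested and lower numbers for a weaker effect), compound 2 gives 35.2%, the higher of the two numbers in hand; its only neighbour is compound 1, which in this assay gives 9.25%. For the measured compounds named here, the single measured step is a number 26 percentage points higher from compound 1 to compound 2 (beyond the scatter), and it is the only comparison that informs the next compound.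

Compound 3, `COc1ccc2nc(C(=O)Nc3c(F)cc(-c4cccc(F)c4)cc3F)c(C)c(C(=O)O)c2c1`, is not yet measured in this assay. Change from compound 2 to compound 3: hydrogen in place of methyl on a saturated chain carbon bound to an oxygen on an aromatic ring. Read one bond further out, ethoxy becomes methoxy. The step from compound 1 to compound 2 changed two things at once, methyl to an oxygen-linked ethyl; compound 3 keeps the oxygen link and drops one carbon of the chain, so by structure it sits between the two measured compounds. The difference of one carbon on the chain is small, so in this assay a step of a number 10.2 percentage points lower from compound 2 to compound 3 (beyond the scatter) is expected, downward if anything and close to the scatter. Compound 3 is therefore estimated at 25%, within 9% to 41%.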

Compound 3, a percentage reported as inhibition, at one concentration (the size of the read-out at that concentration, not a potency): 24.6%
Compound 3: middle estimate off by 0.4 percentage points, on the high side; the measured number falls inside the stated range.
By their numbers in this assay, from the lowest: compound 1; then compound 3; then compound 2.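

In this assay, the change at this position can now be read in two parts, where the earlier step from methyl to ethoxy could not separate the oxygen link from the length of the chain: methoxy in place of methyl on the aromatic carbon gives a number 15.4 percentage points higher from compound 1 to compound 3 (beyond the scatter), and hydrogen in place of methyl on the saturated chain carbon bound to the oxygen gives a number 10.6 percentage points lower from compound 2 to compound 3 (beyond the scatter). Among the compounds shown here, both steps are beyond the usual scatter, so the read-out responds to the exchange of methyl for methoxy and also to the further change from methoxy to ethoxy, giving the order methyl, methoxy, ethoxy across these three compounds with no member going against it. No measurement in hand explains this order.

The three compounds leave open whether a longer chain on the oxygen, such as propoxy or butoxy, would continue this rise or reverse it. They also leave open whether the oxygen link itself is needed, which an amine or a plain propyl chain in the same place would test, and, with a single concentration as the read-out, whether these differences between a stronger and a weaker effect would hold at other concentrations.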